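Reversing a hydroxy-to-trifluoromethyl swap on a longer urea chain

This account rests on a few compounds, and the source may have more. Where it says the series, first, only, none or still open, it means among the compounds named here.

Compound 1, `COc1cc(NC(C)CCCNC(=O)Nc2ccc(C(F)(F)F)cc2)c2ncccc2c1`, in a functional assay on MOLT-4 cells (Homo sapiens) for inhibition, read by MTT assay, with a stated time of 72 h (on this read-out lower numbers stand for stronger inhibition and higher numbers for weaker inhibition), gives 20000 nM.
Compound 2, `COc1cc(NC(C)CCCNC(=O)Nc2ccc(O)cc2)c2ncccc2c1`, in this assay gives 21000 nM.
Compound 3, `COc1cc(NC(C)CCCNC(=O)NNC(=O)Nc2ccc(O)cc2)c2ncccc2c1`, in this assay gives 104000 nM.

Compound 3 has the highest number of the three, so it is the weakest inhibitor in this set. Its nearest neighbour is compound 2, as shown by a 5.0-fold higher number from compound 2 to compound 3 (0.69 log units; beyond the scatter), and the furthest is compound 1, as shown by a 5.2-fold higher number from compound 1 to compound 3 (0.72 log units; beyond the scatter); both steps lie beyond the scatter. Going by the values given here, the not-yet-measured compound 4, `COc1cc(NC(C)CCCNC(=O)NNC(=O)Nc2ccc(C(F)(F)F)cc2)c2ncccc2c1`, keeps the extended chain of compound 3 and changes only one group: trifluoromethyl in place of hydroxy on an aromatic carbon. Among the compounds with values here, one measured step bears directly on this change, in the opposite direction, namely a 1.1-fold higher number from compound 1 to compound 2 (0.02 log units; within the scatter), and it stayed within the scatter. The same swap on compound 3 is therefore expected to give a step of a 1.0-fold lower number from compound 3 to compound 4 (0.02 log units; within the scatter) in this assay, with no move beyond the scatter. Compound 4 is thus estimated at 100000 nM, with a range from 50000 nM to 200000 nM.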

Compound 4, half-maximal inhibitory concentration: 24000 nM
Beside the measured number, compound 4's estimate is 4.2-fold (0.62 log units) above it, and the stated range ends above it.
By their numbers in this assay, from the lowest: compounds 1, 2 and 4 (each within the scatter of the next); then compound 3.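

On the extended chain, trifluoromethyl in place of hydroxy on the aromatic carbon is not a silent change: it gives a 4.3-fold lower number from compound 3 to compound 4 (0.64 log units; beyond the scatter) in this assay. The weak number of compound 3 therefore belongs to the pairing of hydroxy with the extended chain, not to the extended chain alone, since compound 4, which carries that chain, gives 24000 nM. The outcome of this exchange depends on the chain that carries it, something a single pair could not reveal: the same change on two cores in this assay, a 1.1-fold higher number (0.02 log units; within the scatter) from compound 1 to compound 2 and a 4.3-fold higher number (0.64 log units; beyond the scatter) from compound 4 to compound 3, 4.1-fold (0.62 log units) apart, beyond the scatter of two such steps.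

From the compounds shown here alone, whether this dependence holds for other groups in the same place, such as an amine or a carboxylic acid, or on a still longer chain, stays open. Nor do the numbers shown tell why the two chains respond so differently to the same exchange.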